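The source may report more compounds than this note shows. Statements on the series, on what has been measured and on what is new or still open speak of the compounds shown alone.

Measured so far:
compound 1 `CCCCOc1ccc(C2CC(C(=O)NN3CCOCC3)=NN2c2ccc(Cl)cc2Cl)cc1` — 18.1%
compound 2 `COc1ccc(C2CC(C(=O)NN3CCOCC3)=NN2c2ccc(Cl)cc2Cl)cc1` — 9.4%

Among the measured compounds shown here, in a functional assay on the whole organism (strain Zucker) for inhibition, with Rattus norvegicus as the target, with a stated time of 4 h, at a dose of 10 mg/kg by the oral route (on this read-out lower numbers stand for less inhibition and higher numbers for more inhibition at the one dose given (going by the name of the read-out)), compound 2 gives the lower of the two numbers, but the one measured step, a number 8.7 percentage points lower from compound 1 to compound 2 (within the scatter), lies within the scatter, so no order between compound 1 and compound 2 can be read from it. Compound 3 `O=C(NN1CCOCC1)C1=NN(c2ccc(Cl)cc2Cl)C(c2ccc(Br)cc2)C1` differs from compound 2 by bromo in place of methoxy on an aromatic carbon. The measured step concerns hydrogen in place of propyl on the chain bound to the ring oxygen and does not cover an exchange of this kind; nothing measured bears on it directly. The expected step is therefore a number 2.6 percentage points higher from compound 2 to compound 3 (within the scatter), none beyond the scatter. Compound 3 is estimated at 12%, between 0% and 28%.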

Compound 3, a percentage reported as inhibition, in the whole organism at one dose (the size of the read-out at that dose, not a potency): 24.2%
Beside the measured number, compound 3's estimate is 12.2 percentage points below it; the measured number falls inside the stated range.
By their numbers in this assay, from the lowest: compounds 2, 1 and 3 (each within the scatter of the next, the first and the last beyond it).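

In this assay, the position on the aromatic carbon para to a large group responds to the exchange of methoxy for bromo, with a step beyond the scatter: a number 14.8 percentage points higher from compound 2 to compound 3 (beyond the scatter). Bromo in place of butoxy gives no readable order: a number 6.1 percentage points higher from compound 1 to compound 3 (within the scatter). No measurement at hand accounts for the step.

As far as these compounds go, whether chloro, trifluoromethyl or an amine at this position would read with bromo or with methoxy remains open. These numbers come from a single dose, so they say nothing about potency.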